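This account rests on a few compounds, and the source may have more. Where it says the series, first, only, none or still open, it means among the compounds named here.

Measured compounds in the series:
- compound 1 `COc1ccc(/C=N/NC(=O)Nc2ccc(Oc3ccnc4cc(OCCCN5CCCCC5)c(OC)cc34)c(F)c2)cc1`: 126000 nM
- compound 2 `COc1cc2c(Oc3ccc(NC(=O)N/N=C/c4ccc(Cl)cc4Cl)cc3F)ccnc2cc1OCCCN1CCCCC1`: "not determined" (no result reported)

In an ADME assay on PBL cells (Homo sapiens) for cytotoxicity, read by MTT assay, with a stated time of 72 h (a lower number here means a stronger inhibitor, a higher number a weaker inhibitor), compound 1 gives 126000 nM. From the compounds shown here alone, compound 2 gives "not determined" (no result reported) in this assay; the measurement was not reported, so where compound 2 stands on the cytotoxicity read-out is unknown and nothing can be said of a gap between compound 2 and compound 1. The shared core of compound 1 and compound 2 is the same; they differ only in the aryl group on the hydrazone carbon.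

Compound 3 `COc1cc2c(Oc3ccc(NC(=O)N/N=C/c4cccs4)cc3F)ccnc2cc1OCCCN1CCCCC1` is the next compound to be measured in this assay. It differs from compound 2 by thiophen-2-yl in place of 2,4-dichlorophenyl on a carbon with a double bond to nitrogen. Going by the values given here, no step between two measured compounds exists to calibrate this change, and compound 2 itself carries no value, so the expectation for compound 3 rests on compound 1 alone, which gives 126000 nM with the same core.

Compound 3 is therefore expected to show weak cytotoxicity of a similar order to compound 1, estimated at 120000 nM, with a range from 50000 nM to 300000 nM, and a fair chance that only a limit is reported.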

Compound 3, half-maximal inhibitory concentration: 68700 nM
Compound 3: the middle estimate sits 1.7-fold (0.24 log units) above what was measured; measured number inside the range.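

In this assay the series now has its first readable step at this position, the carbon with a double bond to nitrogen: thiophen-2-yl in place of 4-methoxyphenyl gives a 1.8-fold lower number from compound 1 to compound 3 (0.26 log units; within the scatter) and that step stays within the usual scatter. Going by these compounds alone, on this evidence, a five-membered aromatic ring with 1 hetero atom and a six-membered aromatic ring of carbon only cannot be told apart at this position on the shared core, and the single value of compound 1 is no longer the only anchor for the series. No available data bear on why the read-out holds across this change.

From the compounds shown here alone, compound 2 has no number, so 2,4-dichlorophenyl cannot be read against either 4-methoxyphenyl or thiophen-2-yl, and the effect of chlorine on the ring at this position stays open. Also open, going by these compounds, is whether a ring carrying an amine or a carboxylic acid, or a saturated ring such as cyclohexyl, on the same carbon would keep the read-out in this range or move it beyond the scatter.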